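This account rests on a few compounds, and the source may have more. Where it says the series, first, only, none or still open, it means among the compounds named here.

Series notes. Compound 1 `CCOc1ccc(S(=O)(=O)N(C)C(C)C)cc1-c1ncc(C(=O)O)c(=O)[nH]1` is the carboxy member of the first core; in a functional assay on the whole organism (strain Sprague-Dawley) for inhibition, with Rattus norvegicus as the target, with a stated time of 10 min (on this read-out higher numbers stand for an effect only at larger amounts of compound and lower numbers for an effect already at smaller amounts), compound 1 gives only a limit, > 10 mg/kg. Compound 2 `CCOC(=O)c1cnc(-c2cc(S(=O)(=O)N(C)C(C)C)ccc2OCC)[nH]c1=O` differs from it by ethyl in place of hydrogen on an oxygen next to a carbonyl group; in this assay compound 2 likewise returns only a limit, > 10 mg/kg. The step that the two limits leave unreadable from compound 1 to compound 2 cannot be read as a number, both values resting on (the limit of > 10 mg/kg in this assay, at which 2 of the 3 values shown sit). Compound 3 `CCOc1ccccc1-c1ncc(C(=O)O)c(=O)n1C` is built on another core; the difference between the two cores is not broken down here. In this assay compound 3 again gives only a limit, > 50 mg/kg, namely (the limit of > 50 mg/kg in this assay, at which 1 of the 3 values shown sits). Compound 4 `CCOC(=O)c1cnc(-c2ccccc2OCC)n(C)c1=O` differs from compound 3 by ethyl in place of hydrogen on an oxygen next to a carbonyl group, the same change as between the first two compounds. With that earlier step unreadable and compound 3 at a limit, a step that the limit leaves unreadable from compound 3 to compound 4 is expected, most likely reported once more as a limit. Compound 4 is estimated at 70 mg/kg, within 25 mg/kg to 200 mg/kg.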

Compound 4, dose for 50% inhibition: > 40 mg/kg
Compound 4 was reported as a limit (the forecaster's own chance of this, stated with the estimate: 85%); the middle value lies beyond the limit too.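

The step from compound 3 to compound 4 cannot be read, as both values are limits. The compounds shown leave open whether ethyl in place of hydrogen on an oxygen next to a carbonyl group changes the read-out on either core.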